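Distal ring swap on the ring amine of compound 3

The source may hold more compounds than are shown below. What is called first, only, known or untested is meant among the compounds shown, and "the series" means these compounds.

Working notes on the series. In an assay on CHO cells for antagonist activity at transient receptor potential cation channel subfamily V member 1 (Homo sapiens), read by FLIPR (a lower number here means a stronger inhibitor, a higher number a weaker inhibitor), compound 1 `CCCCN(C)c1cc(C(F)(F)F)ccc1CNC(=O)C(C)c1ccc(NS(C)(=O)=O)c(F)c1` gives 1.2 nM and compound 2 `CC1CCN(c2cc(C(F)(F)F)ccc2CNC(=O)C(C)c2ccc(NS(C)(=O)=O)c(F)c2)CC1` gives 0.9 nM; the step of a 1.3-fold lower number from compound 1 to compound 2 (0.12 log units; within the scatter) stays within the scatter. Compound 3 `CC(C(=O)NCc1ccc(C(F)(F)F)cc1N1CCN(C2CCCCC2)CC1)c1ccc(NS(C)(=O)=O)c(F)c1` gives 13.8 nM in this assay, the highest of the three numbers: the steps of a 12-fold higher number from compound 1 to compound 3 (1.06 log units; beyond the scatter) and a 15-fold higher number from compound 2 to compound 3 (1.19 log units; beyond the scatter) are both large and beyond the scatter, so compound 3 is the weakest inhibitor of the measured set.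

Compound 4 `Cc1ccc(N2CCN(c3cc(C(F)(F)F)ccc3CNC(=O)C(C)c3ccc(NS(C)(=O)=O)c(F)c3)CC2)cc1` keeps the core of compound 3 together with the 4-substituted piperazin-1-yl on the aromatic carbon; the change is 4-methylphenyl in place of cyclohexyl on an amine nitrogen in a ring. Going by the values given here, none of the measured steps touches this position: each of them exchanges the whole group on the aromatic carbon, whereas here only the group on the ring amine nitrogen is exchanged. What the measured compounds show is merely that compound 3 lies well above compounds 1 and 2. Among the compounds with values here, no measured step therefore gives a direction for this exchange in this assay, and no step beyond the scatter is expected from it. Compound 4 is expected to give about 14 nM in this assay, within 4 nM to 50 nM, which is an expected step of a 1.0-fold higher number from compound 3 to compound 4 (0.01 log units; within the scatter).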

Compound 4, inhibition constant: 0.7 nM
Compound 4: the middle estimate sits 20-fold (1.30 log units) above what was measured; measured number below the stated range.
By their numbers in this assay, from the lowest: compounds 4, 2 and 1 (each within the scatter of the next); then compound 3.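

Going by these compounds alone, compound 4 gives the first reading of the group on the amine nitrogen of the piperazine ring, since the earlier steps each exchanged the whole group on the aromatic carbon. In this assay, 4-methylphenyl in place of cyclohexyl gives a 20-fold lower number from compound 3 to compound 4 (1.29 log units; beyond the scatter), a large step beyond the scatter, so this distal group alone can move the number substantially. The high number of compound 3 therefore does not follow from the 4-substituted piperazin-1-yl as such: with that ring kept, compound 4 gives 0.7 nM and falls within the scatter of compounds 1 and 2, and no measurement shown accounts for the size of this step.

The exchange alters two things at once, an aromatic ring for a non-aromatic one and an added methyl, so the compounds shown do not separate the two; plain phenyl on the same nitrogen would address that directly. Also open, going by these compounds, is how far the low number extends to other rings at this position, such as 4-chlorophenyl, a pyridine ring or a cyclohexyl ring bearing a methyl.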